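The source may report more compounds than this note shows. Statements on the series, on what has been measured and on what is new or still open speak of the compounds shown alone.

Measured in a physicochemical assay for solubility, read by HPLC; a lower number here means a less soluble compound, a higher number a more soluble compound:
- Compound 1 `CSCC(=O)N1CCN(c2nc(=O)c3cc(C(F)(F)F)cc([N+](=O)[O-])c3s2)CC1`: 15.2 ug/mL
- Compound 2 `O=C(c1ccc(Cl)cc1)N1CCN(c2nc(=O)c3cc(C(F)(F)F)cc([N+](=O)[O-])c3s2)CC1`: 5.19 ug/mL

Compound 2 stands lowest of the two, at 5.19 ug/mL. Compound 3 `O=c1nc(N2CCN(CC3CCCCC3)CC2)sc2c([N+](=O)[O-])cc(C(F)(F)F)cc12` carries cyclohexylmethyl in place of (4-chlorophenyl)carbonyl on an amine nitrogen in a ring. Within the data shown here, the only measured step that bears on this is a 2.9-fold lower number from compound 1 to compound 2 (0.47 log units; beyond the scatter), a modest one that brought in 4-chlorophenyl on a carbonyl carbon. With that group now leaving, a modest rise is expected in this assay, an estimated 1.9-fold higher number from compound 2 to compound 3 (0.28 log units; within the scatter). The estimate for compound 3 is 10 ug/mL, with an expected range of 3 ug/mL to 35 ug/mL.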

Compound 3, solubility: 9.07 ug/mL
Compound 3: the middle estimate sits 1.1-fold (0.04 log units) above what was measured, within the range that was stated.
By their numbers in this assay, from the lowest: compounds 2, 3 and 1 (each within the scatter of the next, the first and the last beyond it).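

In this assay, cyclohexylmethyl in place of (4-chlorophenyl)carbonyl on the amine nitrogen in a ring gives a 1.7-fold higher number from compound 2 to compound 3 (0.24 log units; within the scatter), so this exchange, which also removes the carbonyl, is not resolved from no change. Set against ((methylsulfanyl)methyl)carbonyl, the same group gives a 1.7-fold lower number from compound 1 to compound 3 (0.22 log units; within the scatter), so compound 3 cannot be told apart from either of the others, although those two differ beyond the scatter. Nothing at hand accounts for these numbers. From the compounds shown here alone, it remains open whether a carboxylic acid or a morpholine group on this nitrogen would give a step beyond the scatter.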